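Adding a Trifluoromethyl Group to Compound 2

This account rests on a few compounds, and the source may have more. Where it says the series, first, only, none or still open, it means among the compounds named here.

Of the compounds shown here, two sharing the same core have been measured so far. Compound 1 `CC1=CCCC(C)(C)C1/C=C/C(=O)/C=C/c1cccc(C(F)(F)F)c1` carries a trifluoromethyl group on its aromatic ring, and compound 2 `CC1=CCCC(C)(C)C1/C=C/C(=O)/C=C/c1ccccc1F` carries a fluoro group instead. In a functional assay on CWR22R cells (Homo sapiens) for cytotoxicity, read by MTT assay, with a stated time of 72 h (on this read-out lower numbers stand for stronger inhibition and higher numbers for weaker inhibition), compound 1 gives 2900 nM, while in this assay compound 2 gives 9400 nM. Compound 2 therefore stands at the highest of the two numbers, and its nearest neighbour, compound 1, sits at a lower number by a gap that goes beyond the usual scatter.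

Compound 3 `CC1=CCCC(C)(C)C1/C=C/C(=O)/C=C/c1cc(C(F)(F)F)ccc1F` has not been measured yet. It differs from compound 2 in one place: trifluoromethyl in place of hydrogen on an aromatic carbon, placed meta to a large group and para to a fluoro group. Among the measured compounds shown here, no pair of measured compounds differs in exactly this way, so the size of the step can only be judged from what compound 1 and compound 2 show. Because compound 1 gives 2900 nM, a trifluoromethyl group on this ring goes together with a lower number than the fluoro group alone, since compound 2 gives 9400 nM. The expected step is a 2.7-fold lower number from compound 2 to compound 3 (0.43 log units; beyond the scatter), a lowering of the number beyond the scatter. Compound 3 is estimated to give 3500 nM, with a range from 1500 nM to 8000 nM.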

Compound 3, half-maximal inhibitory concentration: 3500 nM
Compound 3: the middle estimate sits on the measured number at the digits printed; the measured number falls inside the stated range.
By their numbers in this assay, from the lowest: compounds 1 and 3 (each within the scatter of the next); then compound 2.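

In this assay, trifluoromethyl in place of hydrogen on this aromatic carbon, meta to a large group and para to a fluoro group, gives a 2.7-fold lower number from compound 2 to compound 3 (0.43 log units; beyond the scatter) and so provides a direct comparison of the two compounds that differ only in this one place. The reverse question is answered by adding the fluoro group to a ring that already carries trifluoromethyl, which gives a 1.2-fold higher number from compound 1 to compound 3 (0.08 log units; within the scatter) and thus no change that can be told apart from the usual scatter. In this small set, then, the trifluoromethyl step is the one that stands out from the scatter, while nothing shown gives a cause for either step.

On these data alone, whether a methoxy group, an amine or a carboxylic acid on the same aromatic carbon would go with a step of similar size or direction remains open. Also open, as far as these compounds go, is where a compound with hydrogen in place of both the trifluoromethyl and the fluoro group would stand, and so what either group does on a ring that carries neither.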